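Moving the methyl: compound 3 to compound 4

A few compounds are considered here, and "the series" means these few. Any claim that something is new, unique, unknown or untested is made for them only; others in the source may bear on it.

Of the compounds shown here, three have numbers so far in a functional assay on A549 cells (Homo sapiens) for antiproliferative activity, read by MTT assay, with a stated time of 48 h; a lower number here means a stronger inhibitor, a higher number a weaker inhibitor. Compound 1 (`Cc1ccc2nc(NC(c3cn(-c4ccccc4)nc3-c3cccc([N+](=O)[O-])c3)c3c(O)ccc4ccccc34)sc2c1`) gives 57400 nM, and compound 2 (`Cc1cc2nc(NC(c3cn(-c4ccccc4)nc3-c3ccc([N+](=O)[O-])cc3)c3c(O)ccc4ccccc34)sc2cc1C`) gives 41900 nM. Compound 3 (`Cc1cccc(-c2nn(-c3ccccc3)cc2C(Nc2nc3ccccc3s2)c2c(O)ccc3ccccc23)c1`) gives 18500 nM, the lowest of the three numbers, and its gaps to the other two both lie beyond the scatter.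

Compound 4 (`Cc1ccc(-c2nn(-c3ccccc3)cc2C(Nc2nc3ccccc3s2)c2c(O)ccc3ccccc23)cc1`) has the same atoms as compound 3, joined differently. It carries 4-methylphenyl in place of 3-methylphenyl on an aromatic carbon of the five-membered aromatic ring with 2 nitrogen, next to the ring nitrogen: 4-methylphenyl in place of 3-methylphenyl on an aromatic carbon.

For the measured compounds named here, no two measured compounds differ in one place only, so the series offers no direct precedent for this change, and the gaps among the three measured compounds cannot be assigned to any single group. The working expectation therefore starts from compound 3 at 18500 nM, with a wide margin for the missing precedent. The expected step, a 1.1-fold higher number from compound 3 to compound 4 (0.03 log units; within the scatter), stays within the scatter, and no direction is favoured. Compound 4 is estimated at 20000 nM, with an expected range of 9000 nM to 45000 nM.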

Compound 4, half-maximal inhibitory concentration: 57400 nM
Compound 4: middle estimate off by 2.9-fold (0.46 log units), on the low side; the whole stated range lies below it.
By their numbers in this assay, from the lowest: compound 3; then compounds 2, 1 and 4 (each within the scatter of the next).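

In this assay the move of the methyl gives the series its first one-place step: a 3.1-fold higher number from compound 3 to compound 4 (0.49 log units; beyond the scatter), with 4-methylphenyl in place of 3-methylphenyl. The earlier compounds shown here could not show this, as none of them differed in one place only. The result shows that activity at this aromatic carbon of the five-membered aromatic ring with 2 nitrogen depends on where the methyl sits on the phenyl group, even though the leaving and entering groups match in heavy atoms, ring type, hydrogen-bond donors and acceptors, and charge. Nothing at hand accounts for the step, so it stands as an observation only.

The compounds shown leave open whether the same preference holds for other groups on this phenyl ring, such as methoxy or an amine, or for a plain phenyl group at the same carbon. They also cannot say whether it carries over to the nitro-bearing compound 1 and compound 2, which differ from each other in more than one place.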